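The compounds below may be only part of what the source reports. "The series", "measured", "known", "first", "only" and "open" are said of these compounds alone.

Measured compounds:
Compound 1 `O=c1cc(CC(O)(COCc2ccccc2)COCc2ccccc2)[nH]c(=O)[nH]1` — in a functional assay on HeLa cells (Homo sapiens) for antiproliferative activity, read by MTT assay, with a stated time of 72 h (a higher number here means a weaker inhibitor, a lower number a stronger inhibitor), compound 1 gives > 100000 nM, a limit of the assay.
Compound 2 `O=c1cc(CC(COCc2ccccc2)COCc2ccccc2)[nH]c(=O)[nH]1` — in this assay compound 2 gives > 100000 nM, a limit of the assay.
Compound 3 `O=c1cc(CC(O)COCc2ccccc2)[nH]c(=O)[nH]1` — in this assay compound 3 gives > 100000 nM, a limit of the assay.

Compound 3 therefore stands only at a limit, the same point as the two other compounds, as summarised by the limit of > 100000 nM in this assay, at which 3 of the 3 values shown sit. Compound 4 `Cc1c(CC(O)COCc2ccccc2)[nH]c(=O)[nH]c1=O` differs from compound 3 by methyl in place of hydrogen on an aromatic carbon. The steps among the measured compounds are a step that the two limits leave unreadable from compound 1 to compound 2, a step that the two limits leave unreadable from compound 1 to compound 3 and a step that the two limits leave unreadable from compound 2 to compound 3; none of them has a readable size, and none touches the shared core. No direction can be read from these steps, and the step expected here is estimated as a number no higher from compound 3 to compound 4 (the limit leaves the size open), which keeps the expected value at the limit. Compound 4 is estimated at 100000 nM, in the range 30000 nM to 300000 nM.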

Compound 4, half-maximal inhibitory concentration: > 100000 nM
Compound 4: a limit, no number; the forecaster's own chance of this, stated with the estimate: 80%; the middle value lies on the limit itself.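

Compound 4 sits at a limit, as compound 3 does, so no new step can be read between them in this assay: the limit of > 100000 nM in this assay, at which 4 of the 4 values shown sit.

The compounds shown leave open what size, or direction, the methyl step has in this assay.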